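Replacing fluoro by methylamino on the fused core of compound 3

The compounds below may be only part of what the source reports. "The series", "measured", "known", "first", "only" and "open" are said of these compounds alone.

Compound 1, `O=C(Nc1ccc(-n2ncc3c(Cl)cccc32)cc1)Nc1ccc(Cl)c(C(F)(F)F)c1`, 2500 nM
Compound 2, `O=C(Nc1ccc(-n2ncc3c(Br)cccc32)cc1)Nc1ccc(Cl)c(C(F)(F)F)c1`, 1300 nM
Compound 3, `O=C(Nc1ccc(-n2ncc3c(F)cccc32)cc1)Nc1ccc(Cl)c(C(F)(F)F)c1`, 16000 nM

In a functional assay on Bel-7402 cells (Homo sapiens) for cytotoxicity, read by MTT assay, with a stated time of 72 h (a lower number here means a stronger inhibitor, a higher number a weaker inhibitor), compound 3 stands with the highest number of the three measured compounds, and both of its steps to the others lie beyond the scatter. The step of a 6.4-fold higher number from compound 1 to compound 3 (0.81 log units; beyond the scatter) is modest, the step of a 12-fold higher number from compound 2 to compound 3 (1.09 log units; beyond the scatter) is large, while the step of a 1.9-fold lower number from compound 1 to compound 2 (0.28 log units; within the scatter) stays within the scatter. Compound 4, `CNc1cccc2c1cnn2-c1ccc(NC(=O)Nc2ccc(Cl)c(C(F)(F)F)c2)cc1`, is not yet measured; it differs from compound 3 by methylamino in place of fluoro on an aromatic carbon.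

The measured steps that bear on this change are the two that alter the same position of the fused core: each time fluoro is exchanged for another group there, the number falls, by a modest amount in a 6.4-fold higher number from compound 1 to compound 3 (0.81 log units; beyond the scatter) and by a large amount in a 12-fold higher number from compound 2 to compound 3 (1.09 log units; beyond the scatter). Nothing measured speaks to methylamino itself, so the direction is only inferred from fluoro being the worst of the three groups tried. The step of a 5.3-fold lower number from compound 3 to compound 4 (0.73 log units; beyond the scatter) is therefore expected to lower the number, though with wide uncertainty. For compound 4 the estimate in this assay is 3000 nM, with a range from 800 nM to 12000 nM.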

Compound 4, half-maximal inhibitory concentration: 5000 nM
The estimate for compound 4 lay 1.7-fold (0.22 log units) below the measured number, and the stated range covers the measured number.
By their numbers in this assay, from the lowest: compounds 2, 1 and 4 (each within the scatter of the next, the first and the last beyond it); then compound 3.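

In this assay this aromatic carbon proves not to be limited to halogens, since the step of a 3.2-fold lower number from compound 3 to compound 4 (0.51 log units; beyond the scatter) shows that methylamino, which brings one hydrogen-bond donor and one hydrogen-bond acceptor where fluoro counts none, improves on fluoro by a modest margin. That gain has a clear limit, for the step of a 3.8-fold higher number from compound 2 to compound 4 (0.59 log units; beyond the scatter) leaves methylamino short of bromo, while the step of a 2.0-fold higher number from compound 1 to compound 4 (0.30 log units; within the scatter) means that methylamino cannot be told apart from chloro in this assay. The compounds therefore show that a group of a different kind can recover much of what fluoro loses at this position, but no measurement here explains why these groups differ.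

The compounds shown leave open where a primary amine, a dimethylamino group or a methoxy group would stand at this carbon, so the part played by the hydrogen on the nitrogen remains unresolved. Also open, going by these compounds, is whether a longer chain on that nitrogen, such as ethylamino, would close the remaining gap to bromo or widen it.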